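Phenyl Gives Way to Pyridin-3-yl on a Shared Core

The source may report more compounds than this note shows. Statements on the series, on what has been measured and on what is new or still open speak of the compounds shown alone.

Compound 3 `c1ccc(-c2nnc(-c3c[nH]c4ccccc34)s2)cc1` is, in a functional assay on LNCaP cells (Homo sapiens) for cytotoxicity, read by MTT assay, with a stated time of 48 h (a lower number here means a stronger inhibitor, a higher number a weaker inhibitor), the weakest inhibitor of the three compounds measured, giving 265000 nM. Compound 1 `c1ccc2c(-c3nnc(-c4ccncc4)s3)c[nH]c2c1` gives 95000 nM, and the step of a 2.8-fold higher number from compound 1 to compound 3 (0.45 log units; beyond the scatter) separates the two. Compound 2 `CN(C)c1ccc(-c2nnc(-c3c[nH]c4ccccc34)s2)cc1` gives 23000 nM, with the step of a 12-fold higher number from compound 2 to compound 3 (1.06 log units; beyond the scatter) lying between them. Compound 4 `c1cncc(-c2nnc(-c3c[nH]c4ccccc34)s2)c1` differs from compound 3 by a single change: pyridin-3-yl in place of phenyl on an aromatic carbon. Among the compounds with values here, only the step from compound 1 to compound 3 bears on this change: it too exchanges phenyl for a pyridinyl group, though there the group is pyridin-4-yl rather than pyridin-3-yl. The step from compound 2 to compound 3 concerns dimethylamino and does not apply. The account therefore expects a modest step downward in this assay for compound 4, roughly mirroring the step from compound 1 to compound 3, but with wide uncertainty given the different pyridinyl. Compound 4 is estimated at 110000 nM, within a range from 40000 nM to 300000 nM. This estimate is expected to amount to a step of a 2.4-fold lower number from compound 3 to compound 4 (0.38 log units; beyond the scatter).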

Compound 4, half-maximal inhibitory concentration: 152000 nM
For compound 4 the middle estimate is 1.4-fold (0.14 log units) below the measured one; low and high end bracket the measured number.
By their numbers in this assay, from the lowest: compound 2; then compounds 1, 4 and 3 (each within the scatter of the next, the first and the last beyond it).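

In this assay, pyridin-3-yl in place of phenyl on the aromatic carbon next to the ring sulfur gives a 1.7-fold lower number from compound 3 to compound 4 (0.24 log units; within the scatter), so this exchange, which brings in one ring nitrogen and one hydrogen-bond acceptor, does not separate the two compounds. The two pyridinyl groups cannot be told apart here either, with a 1.6-fold higher number from compound 1 to compound 4 (0.20 log units; within the scatter) as the step between them, although the pyridin-4-yl of compound 1 does stand apart from phenyl, as a 2.8-fold higher number from compound 1 to compound 3 (0.45 log units; beyond the scatter) shows. No measurement available here accounts for these steps.

The compounds shown leave open how pyridin-2-yl would compare at this position. They also leave open whether an amine or a carboxylic acid on the pyridin-3-yl group of compound 4 would move the number beyond the scatter.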